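Sulfonyl aryl variation on a piperazinyl indazole series

A few compounds are considered here, and "the series" means these few. Any claim that something is new, unique, unknown or untested is made for them only; others in the source may bear on it.

Measured so far:
compound 1 `CCn1nc(S(=O)(=O)c2cccc3ccccc23)c2cc(N3CCN(C)CC3)ccc21`, 1.7 nM
compound 2 `CN1CCN(c2ccc3[nH]nc(S(=O)(=O)c4ccc(Cl)cc4)c3c2)CC1`, 8.1 nM
compound 3 `O=S(=O)(c1cccc(F)c1)c1n[nH]c2cccc(N3CCNCC3)c12`, 134 nM

In an assay on HeLa cells for displacement of a labelled ligand from 5-hydroxytryptamine receptor 6 (Homo sapiens) (on this read-out lower numbers stand for stronger inhibition and higher numbers for weaker inhibition), compound 2 gives 8.1 nM, the second highest of the three numbers. Compound 1 gives a lower number and compound 3 a higher one, both gaps beyond the scatter; compound 1 is the nearer of the two.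

Compound 4 `CN1CCN(c2ccc3[nH]nc(S(=O)(=O)c4c(Cl)cccc4Cl)c3c2)CC1` is not yet measured. It differs from compound 2 in one place: 2,6-dichlorophenyl in place of 4-chlorophenyl on a sulfonyl sulfur.

For the measured compounds named here, no measured pair shows this change, so its effect is unknown. With compound 2 at 8.1 nM as the anchor, a small step is expected, if any, in either direction and plausibly within the scatter, a 1.5-fold higher number from compound 2 to compound 4 (0.17 log units; within the scatter). Compound 4 is therefore estimated at 12 nM, in the range 3 nM to 50 nM.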

Compound 4, inhibition constant: 2.6 nM
Estimate against measurement, compound 4: 4.6-fold (0.66 log units) above; measured number outside the range, below it.
By their numbers in this assay, from the lowest: compounds 1 and 4 (each within the scatter of the next); then compound 2; then compound 3.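

In this assay, for the compounds shown here, 2,6-dichlorophenyl in place of 4-chlorophenyl on a sulfonyl sulfur gives a 3.1-fold lower number from compound 2 to compound 4 (0.49 log units; beyond the scatter), the first one-place comparison. It shows that the aryl group on this sulfur can move the number beyond the scatter and that a second chlorine is tolerated here. Nothing available explains this step.

Still open, going by these compounds, is whether an unsubstituted phenyl or a pyridyl ring on the sulfonyl sulfur would keep this number, and whether the same change would carry over to the core of compound 3.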